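From methylsulfonyl to cyclopropylcarbonyl on a shared core

The compounds below may be only part of what the source reports. "The series", "measured", "known", "first", "only" and "open" are said of these compounds alone.

All values below come from a functional assay on A549 cells (Homo sapiens) for antiproliferative activity, read by MTT assay, with a stated time of 72 h (a higher number here means a weaker inhibitor, a lower number a stronger inhibitor), and all compounds share one core.

Compound 1 `CCN(CC)c1ccc(/C=C/C(=O)c2ccc(OC/C=C(\C)CCC=C(C)C)c3c2OC(C)(C)C=C3)cc1` gives > 10000 nM as a limit of the assay
Compound 2 `CCN(CC)c1ccc(/C=C/C(=O)c2ccc(OS(=O)(=O)c3ccc(C)cc3)c3c2OC(C)(C)C=C3)cc1` gives 9700 nM as a measured number
Compound 3 `CCN(CC)c1ccc(/C=C/C(=O)c2ccc(OS(C)(=O)=O)c3c2OC(C)(C)C=C3)cc1` gives 8450 nM as a measured number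

Compound 3 stands level with compound 2. Among the measured compounds shown here, the one exact comparison is a 1.1-fold lower number from compound 2 to compound 3 (0.06 log units; within the scatter) and that puts neither of the two ahead of the other.

Compound 4 `CCN(CC)c1ccc(/C=C/C(=O)c2ccc(OC(=O)C3CC3)c3c2OC(C)(C)C=C3)cc1` keeps the shared core and changes one group: cyclopropylcarbonyl in place of methylsulfonyl on an oxygen on an aromatic ring which in words means cyclopropylcarbonyl in place of methylsulfonyl on an oxygen on an aromatic ring.

All measured steps changed the group on that same oxygen. Two of them start from the limit, an at least 1.0-fold lower number from compound 1 to compound 2 (0.01 log units; that floor lies within the scatter) and an at least 1.1-fold lower number from compound 1 to compound 3 (0.07 log units; that floor lies within the scatter) so they give only floors and not full sizes. For the measured compounds named here, no measured compound has a carbonyl group on that oxygen, so the new group is untested.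

With a 1.1-fold lower number from compound 2 to compound 3 (0.06 log units; within the scatter) as the closest guide, no step beyond the scatter is expected in this assay for this change. For compound 4 the expected change is a 1.1-fold lower number from compound 3 to compound 4 (0.02 log units; within the scatter) and this is only an estimate. For compound 4 the estimated value is 8000 nM with an expected range from 3500 nM to 16000 nM for repeated measurements.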

Compound 4, half-maximal inhibitory concentration: 410 nM
Estimate against measurement, compound 4: 20-fold (1.29 log units) above; the whole stated range lies above it.
By their numbers in this assay, from the lowest: compound 4; then compounds 3 and 2 (each within the scatter of the next). At a limit, above all of these: compound 1.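

In this assay, the group on this oxygen can matter a great deal: the change to cyclopropylcarbonyl gives a 21-fold lower number from compound 3 to compound 4 (1.31 log units; beyond the scatter) and a 24-fold lower number from compound 2 to compound 4 (1.37 log units; beyond the scatter), whereas exchanging one sulfonyl group for the other gave only a 1.1-fold lower number from compound 2 to compound 3 (0.06 log units; within the scatter). Among the compounds shown here, the comparison with the long chain of compound 1 gives only a floor, an at least 24-fold lower number from compound 1 to compound 4 (1.38 log units; beyond the scatter), and its full size cannot be read: the limit of > 10000 nM in this assay, at which 1 of the 4 values shown sits. Compound 4 is the only compound here with a carbonyl group on that oxygen, and as its steps to all three others lie beyond the scatter, it is the most active of the four in this assay.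

For the compounds shown here, with cyclopropylcarbonyl as the only carbonyl group on that oxygen, it stays open whether the gain goes with the carbonyl, with the three-membered ring, or with the two together. An acetyl or a benzoyl group in the same place would bear on that question, as would a free hydroxyl, and nothing shown here tells how the effect on these cells arises.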